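Compound 4: the Z-drawn Double Bond in the Nitro Series

The source may report more compounds than this note shows. Statements on the series, on what has been measured and on what is new or still open speak of the compounds shown alone.

Compound 3 `CC(=O)OC/C(=C\c1ccc([N+](=O)[O-])cc1)C(=O)c1ccccc1` gives 26000 nM in a functional assay on HeLa cells (Homo sapiens) for inhibition, read by sulforhodamine B assay, with a stated time of 48 h; a lower number here means a stronger inhibitor of growth, a higher number a weaker inhibitor of growth. Compound 2 `CC(=O)OC/C(=C\c1ccc(F)cc1)C(=O)c1ccccc1` gives 25000 nM in this assay, and a 1.0-fold higher number from compound 2 to compound 3 (0.02 log units; within the scatter), so the two cannot be told apart. Compound 1 `CC(=O)OC/C(=C\c1ccc(Cl)cc1)C(=O)c1ccccc1` gives 3200 nM, and an 8.1-fold higher number from compound 1 to compound 3 (0.91 log units; beyond the scatter); likewise a 7.8-fold higher number from compound 1 to compound 2 (0.89 log units; beyond the scatter). Compound 4 `CC(=O)OC/C(=C/c1ccc([N+](=O)[O-])cc1)C(=O)c1ccccc1` differs from compound 3 only as follows: the two compounds have the same atoms and bonds and differ only in configuration as drawn: 1 of 1 stereo elements differ; a double bond is drawn E in compound 3 and Z in compound 4. None of the three measured steps touches the geometry of the double bond; each swaps one aromatic substituent for another, so none bears on this change. Going by the values given here, with no comparable step to draw on, compound 4 is expected to land near compound 3, with a wide range, the expected step being no change at the digits printed from compound 3 to compound 4 (within the scatter). Compound 4 is therefore estimated at 26000 nM, between 6000 nM and 100000 nM.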

Compound 4, concentration for 50% growth inhibition: 36000 nM
The estimate for compound 4 lay 1.4-fold (0.14 log units) below the measured number, within the range that was stated.
By their numbers in this assay, from the lowest: compound 1; then compounds 2, 3 and 4 (each within the scatter of the next).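

This is the first step shown that touches the double bond rather than an aromatic substituent, and it reads that geometry alone: (the fact that compounds 3 and 4 differ only in the configuration as drawn). In this assay, with nitro on the aromatic carbon, the change from E to Z as drawn gives (a 1.4-fold higher number from compound 3 to compound 4 (0.14 log units; within the scatter)), so the two forms cannot be told apart in this series.

The compounds shown leave open whether the geometry counts equally with chloro in place of nitro, as in compound 1. They also leave open what an amine on the aromatic carbon, or a free alcohol in place of the acetate, would do.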